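Thiophene for phenyl on the shared core

A few compounds are considered here, and "the series" means these few. Any claim that something is new, unique, unknown or untested is made for them only; others in the source may bear on it.

Measured compounds:
compound 1, `c1ccc(-c2cn3ccnc3c(-c3ccc4ncn(C5CCCCC5)c4c3)n2)cc1`, 58.1%
compound 2, `Fc1ccc(-c2cn3ccnc3c(-c3ccc4ncn(C5CCCCC5)c4c3)n2)cc1`, 15.5%

Compound 1 and compound 2 were both tested in a functional assay on NCI-H522 cells (Homo sapiens) for inhibition, read by sulforhodamine B assay, with a stated time of 48 h, tested at 10 uM; on this read-out higher numbers stand for more inhibition at the one concentration tested (going by the name of the read-out) and lower numbers for less inhibition. Compound 1 stands highest of the two numbers; its nearest neighbour is compound 2, reached by a number 42.6 percentage points lower from compound 1 to compound 2 (beyond the scatter), a change on the phenyl ring that swaps fluoro for hydrogen.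

Compound 3, `c1cn2cc(-c3ccsc3)nc(-c3ccc4ncn(C5CCCCC5)c4c3)c2n1`, has not yet been measured in this assay. It differs from compound 1 as follows: thiophen-3-yl in place of phenyl on an aromatic carbon. Among the compounds with values here, no measured step touches this kind of exchange: the one step known, from compound 1 to compound 2, replaces a hydrogen on the phenyl ring rather than the ring itself, so its size cannot be carried over directly. It does show that this assay responds strongly to a single change at this position. Without a closer comparison, a moderate drop from compound 1 is expected, with wide uncertainty, as a number 13.1 percentage points lower from compound 1 to compound 3 (beyond the scatter). Compound 3 is therefore estimated at 45%, in the range 15% to 72%.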

Compound 3, a percentage reported as inhibition, at one concentration (the size of the read-out at that concentration, not a potency): 10.3%
For compound 3 the middle estimate is 34.7 percentage points above the measured one; the measured number lies below the stated range.
By their numbers in this assay, from the lowest: compounds 3 and 2 (each within the scatter of the next); then compound 1.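

In this assay, exchanging the whole ring at this position, with thiophen-3-yl in place of phenyl, gives a number 47.8 percentage points lower from compound 1 to compound 3 (beyond the scatter) and is thus a large step, whereas the earlier compounds had shown only the effect of adding fluoro to the phenyl ring. The two changes to the phenyl ring end at the same level, since thiophen-3-yl in place of 4-fluorophenyl gives a number 5.2 percentage points lower from compound 2 to compound 3 (within the scatter) and so separates the two changed compounds by no more than the usual scatter; among these three compounds, only the unsubstituted phenyl of compound 1 holds the higher number, and none goes against this. Nothing available bears on the cause of this loss.

The compounds shown leave open whether any other ring at this position, such as a pyridine, a furan or thiophen-2-yl, would keep the number of compound 1. They also leave open whether a phenyl ring carrying a different group, such as a methyl, a methoxy or an amine, would lose as much as the fluoro compound does.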